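Removing an Amide Methyl: What to Expect

A few compounds are considered here, and "the series" means these few. Any claim that something is new, unique, unknown or untested is made for them only; others in the source may bear on it.

Compound 2 `CC(=O)N1CCC(C(=O)N2CC[C@@H](C(=O)N(C)Cc3cc(C(F)(F)F)cc(C(F)(F)F)c3)[C@H](c3ccccc3)C2)CC1` stands second highest of the three numbers seen in an assay on IM-9 cells for displacement of a labelled ligand from Substance-P receptor (Homo sapiens), read by scintillation counting, with a stated time of 30 min; on this read-out lower numbers stand for stronger inhibition and higher numbers for weaker inhibition: compound 2 gives 0.098 nM, compound 3 `CCc1ccccc1[C@H]1CN(C(=O)C2CCN(C(C)=O)CC2)CC[C@@H]1C(=O)N(C)Cc1cc(C(F)(F)F)cc(C(F)(F)F)c1` gives 0.064 nM, and compound 1 `CC(=O)NCC(=O)N1CC[C@@H](C(=O)N(C)Cc2cc(C(F)(F)F)cc(C(F)(F)F)c2)[C@H](c2ccccc2)C1` gives 12 nM. Going by the values given here, the one single-change step measured, a 120-fold lower number from compound 1 to compound 2 (2.09 log units; beyond the scatter), alters a group on a carbonyl carbon rather than the amide nitrogen, so it does not bear on the change to compound 4 `CC(=O)N1CCC(C(=O)N2CC[C@@H](C(=O)NCc3cc(C(F)(F)F)cc(C(F)(F)F)c3)[C@H](c3ccccc3)C2)CC1`, which is hydrogen in place of methyl on an amide-type nitrogen. Among the compounds with values here, no measured step covers this kind of change, so only a cautious guess is possible: a modest weakening is expected. Compound 4 is estimated at 0.4 nM, within a range from 0.08 nM to 2 nM, meaning an expected 4.1-fold higher number from compound 2 to compound 4 (0.61 log units; beyond the scatter).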

Compound 4, half-maximal inhibitory concentration: 2.7 nM
The estimate for compound 4 lay 6.8-fold (0.83 log units) below the measured number, outside the stated range (above it).
By their numbers in this assay, from the lowest: compounds 3 and 2 (each within the scatter of the next); then compound 4; then compound 1.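

In this assay the swap of methyl for hydrogen on the amide-type nitrogen gives a 28-fold higher number from compound 2 to compound 4 (1.44 log units; beyond the scatter) and so weakens inhibition. Going by these compounds alone, this is the first measured change at this nitrogen, and it shows that a single carbon here counts for a great deal, even with the rest of the molecule unchanged. Nothing available here gives a reason for the size of this step.

As far as these compounds go, whether a cyclopropyl group or a longer chain on this nitrogen would keep the inhibition of compound 2 remains open. So does whether the same swap would give a similar step on compound 3.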